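Compound 1 to compound 4: chloro exchanged for methoxy

The source may report more compounds than this note shows. Statements on the series, on what has been measured and on what is new or still open speak of the compounds shown alone.

Measured in a functional assay on U-87MG ATCC cells for antiproliferative activity against U-87 MG (Homo sapiens), read by MTT assay, with a stated time of 48 h; a lower number here means a stronger inhibitor, a higher number a weaker inhibitor:
- compound 1 `COc1ccc(-c2nc(C)c(C(=O)CSc3nc(N)c(C#N)c(-c4ccc(Cl)cc4)n3)s2)cc1`: 4540 nM
- compound 2 `Cc1nc(-c2ccccc2)sc1C(=O)CSc1nc(N)c(C#N)c(-c2ccc(Cl)cc2)n1`: 10800 nM
- compound 3 `Cc1nc(-c2ccccc2)sc1C(=O)CSc1nc(-c2cccc(Cl)c2)c(C#N)c(=O)[nH]1`: 28200 nM

Compound 1 gives the lowest number of the three, and its steps to both others lie beyond the scatter. Compound 4 `COc1ccc(-c2nc(C)c(C(=O)CSc3nc(N)c(C#N)c(-c4ccc(OC)cc4)n3)s2)cc1` keeps the core of compound 1 and carries methoxy in place of chloro on an aromatic carbon, para to a large group, turning 4-chlorophenyl into 4-methoxyphenyl (methoxy in place of chloro on an aromatic carbon).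

Among the compounds with values here, only one measured step changes a single place, a 2.4-fold higher number from compound 1 to compound 2 (0.38 log units; beyond the scatter). It is modest and swaps methoxy for hydrogen at a different aromatic carbon, so it bears only indirectly on this exchange. Within the data shown here, compound 3 differs from compound 1 in more than one place and isolates no step. Among the measured compounds shown here, no measured compound tests the chloro-to-methoxy exchange itself, so no step beyond the scatter is expected in this assay, and the direction remains open.

The expected change is a 1.2-fold higher number from compound 1 to compound 4 (0.08 log units; within the scatter). Compound 4 is estimated at 5500 nM, with an expected range of 2000 nM to 15000 nM.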

Compound 4, half-maximal inhibitory concentration: 1560 nM
The estimate for compound 4 lay 3.5-fold (0.55 log units) above the measured number, and the stated range ends above it.
By their numbers in this assay, from the lowest: compound 4; then compound 1; then compound 2; then compound 3.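

In this assay the position carrying the 4-chlorophenyl group responds to exchange: methoxy in place of chloro gives a 2.9-fold lower number from compound 1 to compound 4 (0.46 log units; beyond the scatter), so chloro is not needed there for the activity seen with the core of compound 1. Read with a 2.4-fold higher number from compound 1 to compound 2 (0.38 log units; beyond the scatter), which concerns a different aromatic carbon, the methoxy-bearing member gives the lower number in both single-place pairs, and neither pair goes against this. Nothing available accounts for the lower number at this position.

As far as these compounds go, whether the effect is specific to methoxy remains open, as a hydroxy group, an ethoxy group or a dimethylamino group at the same place would be needed to tell. Also open, from the compounds shown here alone, is whether a fluoro group in place of chloro would keep the number of compound 1 or move it.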